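The source may hold more compounds than are shown below. What is called first, only, known or untested is meant among the compounds shown, and "the series" means these compounds.

In an ADME assay on cells (Fibroblast, Gallus gallus) for cytotoxicity, read by CCK-8 assay, with a stated time of 48 h (on this read-out lower numbers stand for higher toxicity in this test and higher numbers for lower toxicity in this test), compound 1 `CCC(CC)O[C@@H]1C=C(C(=O)O)C[C@H](NCc2ccc(OC)cc2)[C@H]1NC(C)=O` gives > 200000 nM as a limit of the test, not as a number. Compound 2 `CCC(CC)O[C@@H]1C=C(C(=O)O)C[C@H](NCc2ccc(Sc3cccs3)cc2)[C@H]1NC(C)=O` gives > 200000 nM and this too is a limit. Compound 2 therefore has no exact number of its own, and the picture so far is the limit of > 200000 nM in this assay, at which 2 of the 2 values shown sit, with nothing more precise behind it. Going by the values given here, the only measured step, in which (thiophen-2-yl)sulfanyl takes the place of methoxy on an aromatic carbon, is a step that the two limits leave unreadable from compound 1 to compound 2 and so offers no size to carry forward.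

Compound 3 `CCC(CC)O[C@@H]1C=C(C(=O)O)C[C@H](NCc2ccc(Sc3ccccc3)cc2)[C@H]1NC(C)=O` differs from compound 2 in one place: phenyl in place of thiophen-2-yl on a sulfur. Among the compounds with values here, no step beyond the usual scatter is expected in this assay because the limit of > 200000 nM in this assay, at which 2 of the 2 values shown sit, is the only guide available. The expected step is a number no higher from compound 2 to compound 3 (the limit leaves the size open) and it should be read as a rough expectation. Compound 3 may well be reported only as a limit again. For compound 3 the estimated value is 200000 nM with an expected range from 100000 nM to 400000 nM.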

Compound 3, half-maximal cytotoxic concentration: > 200000 nM
Compound 3 gave a limit, no number; the forecaster's own chance of this, stated with the estimate: 85%; the middle value lies on the limit itself.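

Compound 1, compound 2 and compound 3 all stop at a limit of the test in this assay, not at a number, so no step among them can be read: the limit of > 200000 nM in this assay, at which 3 of the 3 values shown sit.

The compounds shown leave open whether phenyl and thiophen-2-yl on the sulfur differ at all in this assay, and what concentration, if any, would show toxicity for each compound.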